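Shortening the side chain of compound 2

A few compounds are considered here, and "the series" means these few. Any claim that something is new, unique, unknown or untested is made for them only; others in the source may bear on it.

Values from a functional assay on HBL-100 cells (Homo sapiens) for antiproliferative activity, read by sulforhodamine B assay, with a stated time of 48 h (on this read-out higher numbers stand for weaker inhibition of growth and lower numbers for stronger inhibition of growth), for the series:
Compound 1 `CC1CCC(C(C)C)C(OC(=O)C#CC(O/C=C/C(=O)OC2CC(C)CCC2C(C)C)C(C)C)C1` gives > 100000 nM as a limit of the assay
Compound 2 `COC(=O)C#CC(CC(C)C)O/C=C/C(=O)OC` gives 330 nM as its value
Compound 3 `COC(=O)C#CC(C[C@@H](C)CCC=C(C)C)O/C=C/C(=O)OC` gives 3100 nM as its value
Compound 4 `COC(=O)C#CC(C)O/C=C/C(=O)OC` awaits measurement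

The entry for compound 1 is a limit and not a number. Compound 2 holds the lower of the two actual numbers, and compound 3 is its nearest neighbour. The next change is hydrogen in place of isopropyl on a saturated chain carbon, two bonds along the chain from an oxygen on an unsaturated carbon and a triple-bonded carbon and amounts to hydrogen in place of isopropyl on a saturated chain carbon, two bonds along the chain from an oxygen on an unsaturated carbon and a triple-bonded carbon. Cut one bond further out, this reads isobutyl to methyl. Among the measured compounds shown here, only one measured step bears on it: a 9.4-fold higher number from compound 2 to compound 3 (0.97 log units; beyond the scatter) for a change that adds to the chain of compound 2 rather than shortening it. That single step sets no trend for a shorter chain, so it serves only as a guide to size. Compound 2 already sits at the low end of the numbers, so a rise smaller than that step is expected, though no change remains possible. The expected result is a 2.4-fold higher number from compound 2 to compound 4 (0.38 log units; beyond the scatter) in this assay on this reasoning. For compound 4 the estimate is 800 nM with an expected range of 150 nM to 4000 nM for the coming measurement.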

Compound 4, concentration for 50% growth inhibition: 300 nM
The estimate for compound 4 lay 2.7-fold (0.43 log units) above the measured number, within the range that was stated.
By their numbers in this assay, from the lowest: compounds 4 and 2 (each within the scatter of the next); then compound 3. At a limit, above all of these: compound 1.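

In this assay, hydrogen in place of isopropyl on a saturated chain carbon, two bonds along the chain from an oxygen on an unsaturated carbon and a triple-bonded carbon, gives a 1.1-fold lower number from compound 2 to compound 4 (0.04 log units; within the scatter), so the change from isobutyl to methyl leaves the read-out unmoved. Among the compounds shown here, the only earlier step at this side chain, a 9.4-fold higher number from compound 2 to compound 3 (0.97 log units; beyond the scatter), came from adding to the chain and could not show whether the isopropyl end of compound 2 was needed; compound 4 shows that growth inhibition on this read-out persists without it. Across compounds 2, 3 and 4, the side chain therefore accepts this shortening with no change beyond the scatter, while the addition of 3-methylbut-2-en-1-yl is the only change shown that moves the number.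

No measurement among those shown accounts for why removing isopropyl leaves the number in place. The compounds shown leave open what a phenyl ring, a hydroxymethyl group or an unbranched pentyl chain would do in place of the methyl of compound 4.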